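Urea series: varying the aryl substituent next to the pyridine nitrogen

The compounds below may be only part of what the source reports. "The series", "measured", "known", "first", "only" and "open" are said of these compounds alone.

Measured so far:
- compound 1 `O=C(NCc1ccc(C(F)(F)F)nc1N1CCCC1)Nc1cccc2c(=O)[nH]ccc12`: 258 nM
- compound 2 `O=C(NCc1ccc(C(F)(F)F)nc1SC1CCCCC1)Nc1cccc2c(=O)[nH]ccc12`: 69.3 nM

Compound 2 stands lowest of the two numbers in an assay on CHO cells for agonist activity at transient receptor potential cation channel subfamily V member 1 (Homo sapiens); on this read-out higher numbers stand for an effect only at larger amounts of compound and lower numbers for an effect already at smaller amounts; its nearest neighbour is compound 1, and the step of a 3.7-fold lower number from compound 1 to compound 2 (0.57 log units; beyond the scatter) lies beyond the scatter. Within the data shown here, the series has only this one step, a swap of one ring substituent for another on the same aromatic carbon of the shared core.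

The next compound, compound 3 `CC(C)c1cccc(-c2nc(C(F)(F)F)ccc2CNC(=O)Nc2cccc3c(=O)[nH]ccc23)c1`, takes the same position in a different direction: 3-isopropylphenyl in place of cyclohexylsulfanyl on an aromatic carbon. Among the measured compounds shown here, no measured pair shows an aromatic ring entering at this site, so the only step that bears on the change is a 3.7-fold lower number from compound 1 to compound 2 (0.57 log units; beyond the scatter), which shows that this position tolerates a large, non-polar substituent and that the number moved modestly when one was exchanged for another. On that basis a step of similar or smaller size is expected, in either direction, with no firm reason to expect one beyond the scatter; the estimate is a 1.2-fold higher number from compound 2 to compound 3 (0.06 log units; within the scatter). Compound 3 is therefore expected to give 80 nM in this assay, within 25 nM to 250 nM.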

Compound 3, half-maximal effective concentration: 3.07 nM
For compound 3 the middle estimate is 26-fold (1.42 log units) above the measured one, outside the stated range (below it).
By their numbers in this assay, from the lowest: compound 3; then compound 2; then compound 1.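

In this assay, the step of a 23-fold lower number from compound 2 to compound 3 (1.35 log units; beyond the scatter) shows that an aromatic ring is accepted on this aromatic carbon next to the ring nitrogen, and that 3-isopropylphenyl gives a far lower number here than cyclohexylsulfanyl. The full span across the series, an 84-fold lower number from compound 1 to compound 3 (1.92 log units; beyond the scatter), shows that the group at this position can move the read-out much further than the modest exchange between pyrrolidin-1-yl and cyclohexylsulfanyl had indicated, and compound 3 now stands lowest of the three, with both of its steps beyond the scatter. No measured information is available to explain why 3-isopropylphenyl gives this result.

With a single aromatic group at this position, the compounds shown cannot separate the contribution of the phenyl ring from that of its isopropyl group, and an unsubstituted phenyl would bear directly on that question. On these data alone, it also remains open whether a carboxylic acid or a primary amine on the ring would be accepted here, and whether the order of the three groups would hold with a nitrile in place of trifluoromethyl.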